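A new group on the amide nitrogen of compound 2

The compounds below may be only part of what the source reports. "The series", "measured", "known", "first", "only" and "open" are said of these compounds alone.

- compound 1 `Cc1c(C(=O)Nc2ccc(Cl)cn2)nn(C)c1-c1ccc(F)cc1` with 3.65 h
- compound 2 `Cc1nc(C(=O)Nc2cccc(F)n2)c(C)n1-c1ccc(F)cc1` with 1.13 h

Both numbers come from an ADME assay on microsomes from liver (Rattus norvegicus) for metabolic stability (on this read-out higher numbers stand for a longer-lived compound and lower numbers for a shorter-lived compound), and are the only ones at hand. Compound 2 stands lowest of the two at 1.13 h while compound 1 at 3.65 h lies higher, a gap beyond the usual scatter. Compound 3 `Cc1nc(NC(=O)c2nc(C)n(-c3ccc(F)cc3)c2C)ccc1F` has not yet been measured. It has 5-fluoro-6-methylpyridin-2-yl in place of 6-fluoropyridin-2-yl on an amide-type nitrogen and otherwise matches compound 2. Among the measured compounds shown here, no measured pair shows what a change at this place does, so the data offer no direct guide. In this assay a slightly higher number is expected, with no step beyond the scatter. The estimated change is a 1.2-fold higher number from compound 2 to compound 3 (0.06 log units; within the scatter) and it rests on compound 2 at 1.13 h as the starting point. For compound 3 the expected half-life is 1.3 h with an estimated range from 0.5 h to 2.9 h for a single measurement.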

Compound 3, half-life: 0.733 h
Beside the measured number, compound 3's estimate is 1.8-fold (0.25 log units) above it; low and high end bracket the measured number.
By their numbers in this assay, from the lowest: compounds 3 and 2 (each within the scatter of the next); then compound 1.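

Among the compounds shown here, this is the first step read at this place. Putting 5-fluoro-6-methylpyridin-2-yl in place of 6-fluoropyridin-2-yl on an amide-type nitrogen gives a 1.5-fold lower number from compound 2 to compound 3 (0.19 log units; within the scatter) in this assay, so on this read-out compound 2 and compound 3 cannot be told apart, and this change, with its one extra heavy atom, leaves the half-life within repeat variation. Nothing at hand bears on why the half-life responds in this way.

The compounds shown do not separate what the methyl group and the fluorine of the new group each contribute, nor do they show whether the same change would behave alike on the core of compound 1. A methoxy or dimethylamino group on this pyridine ring also remains an open case, and it could yet show whether this place can move the half-life beyond the scatter.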